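A Cyclopropyl Returns to the Side Chain of Compound 2

The source may hold more compounds than are shown below. What is called first, only, known or untested is meant among the compounds shown, and "the series" means these compounds.

Among the compounds with values here, compound 2 `CCCC(C)n1c(=O)c(C)nc2c(-c3ccc(Cl)cc3Cl)ccnc21` holds the second highest of the three numbers measured so far in a functional assay for antagonist activity at corticotropin-releasing factor receptor 1 (Rattus norvegicus) (on this read-out lower numbers stand for stronger inhibition and higher numbers for weaker inhibition), where compound 2 gives 62 nM. Compound 1 `CC[C@H](C1CC1)n1c(=O)c(C)nc2c(-c3ccc(Cl)cc3Cl)ccnc21` gives 8.2 nM, and compound 3 `CCC(C1CC1)n1c(=O)c(C)nc2c(-c3cc(C)c(C)c(C)c3C)ccnc21` gives 340 nM. Compound 4 `CCCC(C1CC1)n1c(=O)c(C)nc2c(-c3ccc(Cl)cc3Cl)ccnc21` has not yet been measured; it differs from compound 2 by cyclopropyl in place of methyl on a saturated chain carbon bound to an aromatic nitrogen and a saturated chain carbon. Within the data shown here, one measured step bears on this change: a 7.6-fold higher number from compound 1 to compound 2 (0.88 log units; beyond the scatter), in which a cyclopropyl-bearing branch gave way to a methyl-bearing one. The change to compound 4 runs the other way, putting a cyclopropyl back onto the branch carbon while leaving the rest of compound 2 untouched. Compound 3 also carries a cyclopropyl branch, but with a different aromatic ring, so only its own value can be noted. A step of roughly the size seen between compound 1 and compound 2 is therefore expected, toward a lower number in this assay. For compound 4 the estimated value is 12 nM, with a range from 4 nM to 40 nM. This amounts to an expected 5.2-fold lower number from compound 2 to compound 4 (0.71 log units; beyond the scatter).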

Compound 4, half-maximal inhibitory concentration: 4.3 nM
Compound 4: middle estimate off by 2.8-fold (0.45 log units), on the high side; the measured number falls inside the stated range.
By their numbers in this assay, from the lowest: compounds 4 and 1 (each within the scatter of the next); then compound 2; then compound 3.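

In this assay, the step to a cyclopropyl a 14-fold lower number from compound 2 to compound 4 (1.16 log units; beyond the scatter) changes only the group on the saturated chain carbon bound to an aromatic nitrogen, so it isolates the effect of that group with the propyl part of the 1-methylbutyl chain left in place, which the earlier step, where the chain changed too, could not do. Exchanging 1-cyclopropylpropyl for 1-cyclopropylbutyl gives a 1.9-fold lower number from compound 1 to compound 4 (0.28 log units; within the scatter), so these two side chains cannot be told apart on this read-out. No measurement at hand explains the effect of the cyclopropyl.

As far as these compounds go, whether a cyclobutyl on the same carbon, or a longer chain such as 1-cyclopropylpentyl, would keep the number this low stays open. From the compounds shown here alone, compound 3 has no partner here that differs from it in one place, so whether cyclopropyl has the same effect with its aromatic ring also stays open.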